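The source may report more compounds than this note shows. Statements on the series, on what has been measured and on what is new or still open speak of the compounds shown alone.

In an assay on membranes from HEK293 cells for displacement of a labelled ligand from adenosine receptor A2b (Homo sapiens), read by scintillation counting, with a stated time of 30 min, tested at 1 uM (on this read-out higher numbers stand for more inhibition at the one concentration tested (going by the name of the read-out) and lower numbers for less inhibition), the three measured compounds all give small numbers. Compound 1, `CC1=C(C(=O)OCC(C)C)C(c2ccoc2)NC(=S)N1`, gives 1%. Compound 2, `CC1=C(C(N)=O)C(c2ccoc2)NC(=O)N1`, gives 6%, and compound 3, `CC1=C(C(N)=O)C(c2ccsc2)NC(=O)N1`, gives 1%. For the measured compounds named here, the one measured step, a number 5 percentage points lower from compound 2 to compound 3 (within the scatter), lies within the scatter, so compound 3 stands level with compound 1 at the digits printed, and compound 2 lies within the scatter of both.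

Compound 4, `CC1=C(C(=O)SC(C)C)C(c2ccsc2)NC(=O)N1`, is the next in line. It differs from compound 3 in one place: isopropylsulfanyl in place of amino on a carbonyl carbon. Going by the values given here, no measured step touches this carbonyl carbon; the only measured step exchanges the ring on a saturated ring carbon and was small. Among the compounds with values here, compound 1 carries an ester on this carbonyl carbon and also sits at the low end of the read-out, but it differs from compound 3 in two places, so its value shows only that such a change at this position need not lift the number. The expected step is therefore a number 2 percentage points higher from compound 3 to compound 4 (within the scatter), nothing beyond the scatter. Compound 4 is estimated to give 3%, with a range from -8% to 15%.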

Compound 4, a percentage reported as inhibition, at one concentration (the size of the read-out at that concentration, not a potency): 14%
Compound 4: the middle estimate sits 11 percentage points below what was measured; low and high end bracket the measured number.
By their numbers in this assay, from the lowest: compounds 1, 3, 2 and 4 (each within the scatter of the next, the first and the last beyond it).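

For the compounds shown here, the step of a number 13 percentage points higher from compound 3 to compound 4 (beyond the scatter) is the first in this assay to lie beyond the scatter, and it falls on the carbonyl carbon whose other neighbour is the double-bonded ring carbon, whereas the earlier step of a number 5 percentage points lower from compound 2 to compound 3 (within the scatter), on the saturated ring carbon, stayed within it. The number at this carbonyl carbon can therefore move when isopropylsulfanyl, with its 4 heavy atoms and no hydrogen-bond donor, takes the place of amino, with its 1 heavy atom and 1 hydrogen-bond donor, although the gain is modest and compound 4 still gives only 14% at the one concentration tested. Nothing at hand says what lies behind this rise.

This single exchange changes several things at once, so the compounds shown leave open whether the sulfur, the branched isopropyl group or the loss of the amino group carries the step; an isopropoxy ester, a dimethylamino amide or a longer thioester chain on the same carbonyl carbon would separate these. On these data alone, it also remains open whether the same exchange gives a similar step with furan-3-yl in place of thiophen-3-yl.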